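Formyl on compound 2: the expected step

The source may report more compounds than this note shows. Statements on the series, on what has been measured and on what is new or still open speak of the compounds shown alone.

In a functional assay on HeLa cells (Homo sapiens) for antiproliferative activity, read by MTT assay, with a stated time of 48 h (a lower number here means a stronger inhibitor, a higher number a weaker inhibitor), compound 2 `COc1cc(-c2nnc3c(OC)cc(-c4ccc5c(ccn5C)c4)cn23)cc(OC)c1OC` gives 15 nM, the lower of the two numbers available. Compound 3 `COc1cc(-c2nnc3c(OC(C)C)cc(-c4ccc5c(ccn5C)c4)cn23)cc(OC)c1OC` gives 503 nM. Compound 1 `COc1cc(-c2nnc3c(OC)cc(-c4ccc5[nH]cc(C=O)c5c4)cn23)cc(OC)c1OC` gives > 10000 nM, which is a limit of the assay.

Compound 4 `COc1cc(-c2nnc3c(OC)cc(-c4ccc5c(c4)c(C=O)cn5C)cn23)cc(OC)c1OC` carries one change: formyl in place of hydrogen on an aromatic carbon. This is formyl in place of hydrogen on an aromatic carbon, two ring bonds from the ring nitrogen.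

The closest guide is an at least 660-fold lower number from compound 1 to compound 2 (2.82 log units; beyond the scatter), with 1-methyl-1H-indol-5-yl in place of 3-formyl-1H-indol-5-yl on an aromatic carbon. That large step also includes the methyl group, so it cannot be assigned to the formyl alone. It therefore sets a ceiling more than a direct measure. The other measured step, a 34-fold higher number from compound 2 to compound 3 (1.53 log units; beyond the scatter), concerns isopropyl in place of methyl on an oxygen on an aromatic ring, a different kind of change, and offers only a sense of how far one small change can move this series.

A large move toward a higher number is expected, namely a 20-fold higher number from compound 2 to compound 4 (1.30 log units; beyond the scatter). For compound 4 the estimated value in this assay is 300 nM, with an expected range of 40 nM to 3000 nM.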

Compound 4, half-maximal inhibitory concentration: 820 nM
For compound 4 the middle estimate is 2.7-fold (0.44 log units) below the measured one; the range from low to high includes it.
By their numbers in this assay, from the lowest: compound 2; then compounds 3 and 4 (each within the scatter of the next). At a limit, above all of these: compound 1.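

In this assay, formyl on this aromatic carbon, two ring bonds from the ring nitrogen, weakens the compound substantially on its own: a 55-fold higher number from compound 2 to compound 4 (1.74 log units; beyond the scatter). This separates the two changes combined in the earlier step between compound 1 and compound 2: with formyl kept in place, methyl in place of hydrogen on the aromatic nitrogen still gives an at least 12-fold lower number from compound 1 to compound 4 (1.08 log units; beyond the scatter), so each change moves the number beyond the scatter. Compound 1 stands at a limit, so this second step is only a bound and its full size remains unknown: the limit of > 10000 nM in this assay, at which 1 of the 4 values shown sits.

Going by these compounds, it remains open whether the loss is particular to formyl or extends to other groups on this carbon, such as a nitrile, a hydroxymethyl or an aminomethyl group. Also open, on these data alone, is how formyl on this carbon would combine with isopropyl on the oxygen.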